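Ring-nitrogen aryl change from compound 3 to compound 4

The source may report more compounds than this note shows. Statements on the series, on what has been measured and on what is new or still open speak of the compounds shown alone.

Compound 3 `O=C(NCCCCc1ccccc1)c1cccc(C2SCC(=O)N2c2ccccc2F)c1` carries a 2-fluorophenyl on the amide-type nitrogen in the ring. In a functional assay on 143B cells (Homo sapiens) for inhibition, read by CCK-8 assay, with a stated time of 72 h, tested at 1 uM (on this read-out higher numbers stand for more inhibition at the one concentration tested (going by the name of the read-out) and lower numbers for less inhibition), compound 3 gives 59%, the highest of the three numbers at hand. Compound 1 `CCN1C(=O)CSC1c1cccc(C(=O)NCCCCc2ccccc2)c1`, with ethyl at that nitrogen, gives 40% in this assay, and compound 2 `COc1cccc(OC)c1N1C(=O)CSC1c1cccc(C(=O)NCCCCc2ccccc2)c1`, with 2,6-dimethoxyphenyl there, gives 31%. The steps ran a number 19 percentage points higher from compound 1 to compound 3 (beyond the scatter) and a number 28 percentage points higher from compound 2 to compound 3 (beyond the scatter), both beyond the scatter, while a number 9 percentage points lower from compound 1 to compound 2 (within the scatter) stayed within it.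

Compound 4 `CC(F)(F)c1cccc(N2C(=O)CSC2c2cccc(C(=O)NCCCCc3ccccc3)c2)c1` differs from compound 3 by a group of 10 heavy atoms (8 carbon, 2 fluorine; one six-membered aromatic ring of carbon only) in place of a group of 7 heavy atoms (6 carbon, 1 fluorine; one six-membered aromatic ring of carbon only), on an amide-type nitrogen in a ring. The two measured steps onto the 2-fluorophenyl show that the group on this nitrogen moves this assay by a modest amount, and that another aryl group, 2,6-dimethoxyphenyl in compound 2, did not shift the number beyond the scatter relative to compound 1. For the measured compounds named here, no measured step covers an aryl group of this size with two fluorines at this position, so the direction is open. The expectation for compound 4 is a step of a number 11 percentage points lower from compound 3 to compound 4 (beyond the scatter), a somewhat lower number than compound 3, because compound 2 gives 31%. The estimate for compound 4 is 48%, with a range from 22% to 72%.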

Compound 4, a percentage reported as inhibition, at one concentration (the size of the read-out at that concentration, not a potency): 1%
The estimate for compound 4 lay 47 percentage points above the measured number; measured number below the stated range.
By their numbers in this assay, from the lowest: compound 4; then compounds 2 and 1 (each within the scatter of the next); then compound 3.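

In this assay, the group of 10 heavy atoms (8 carbon, 2 fluorine) on the amide-type nitrogen in a ring gives a number 58 percentage points lower from compound 3 to compound 4 (beyond the scatter), along with a number 39 percentage points lower from compound 1 to compound 4 (beyond the scatter) and a number 30 percentage points lower from compound 2 to compound 4 (beyond the scatter), so it sits beyond the scatter under all three other groups at this position. The earlier compounds shown here showed only modest movement here, whereas compound 4 shows that a change at this nitrogen can take the read-out at the one concentration tested almost to nothing, and that a six-membered aromatic ring of carbon only does not in itself preserve the number; heavy-atom count does not set it either, since compound 2 and compound 4 match in that count yet differ beyond the scatter. No measurement at hand bears on why the number falls.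

Still open, going by these compounds, is whether the loss follows the two fluorines or the carbon framework of the entering group, a question that an unsubstituted phenyl, a 2-chlorophenyl or a 2-methoxyphenyl on this nitrogen would help to settle. Also open, on these data alone, is whether the 2-fluorophenyl result in compound 3 holds when the four-carbon chain to the terminal phenyl is replaced by a shorter chain or an amine-bearing chain.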